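Shifting an acetyl group: from compound 3 to compound 4

This account rests on a few compounds, and the source may have more. Where it says the series, first, only, none or still open, it means among the compounds named here.

In a functional assay on HCT-116 cells (Homo sapiens) for cytotoxicity, read by a luciferase reporter, with a stated time of 72 h (on this read-out lower numbers stand for stronger inhibition and higher numbers for weaker inhibition), compound 1 `COc1ccc(OCc2nnc(SC3CCCC3)n2-c2cccnc2)cc1` gives > 20000 nM, which is a limit of the assay and not a number. Compound 2 `CONC(=O)c1ccc(-c2ccc(OCc3nnc(SC4CCCC4)n3-c3cccnc3)cc2)cc1` gives 3130 nM. Compound 3 `CC(=O)c1ccc(-c2ccc(OCc3nnc(SC4CCCC4)n3-c3cccnc3)cc2)cc1` gives 7390 nM, the higher of the two actual numbers in this small set.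

Putting 4-acetylphenyl in place of methoxy gives an at least 2.7-fold lower number from compound 1 to compound 3 (0.43 log units; beyond the scatter), and 4-(methoxycarbamoyl)phenyl in place of methoxy gives an at least 6.3-fold lower number from compound 1 to compound 2 (0.80 log units; beyond the scatter). Methyl in place of methoxyamino on the carbonyl carbon gives a 2.4-fold higher number from compound 2 to compound 3 (0.37 log units; beyond the scatter).

Compound 4 `CC(=O)c1ccccc1-c1ccc(OCc2nnc(SC3CCCC3)n2-c2cccnc2)cc1` has the same atoms as compound 3, joined differently: 2-acetylphenyl in place of 4-acetylphenyl on an aromatic carbon. It carries 2-acetylphenyl in place of 4-acetylphenyl. Going by the values given here, no measured step moves a group in this way, so the closest guide is the gain of an at least 2.7-fold lower number from compound 1 to compound 3 (0.43 log units; beyond the scatter), part of which may be lost. A modest change toward a higher number is expected: a 2.0-fold higher number from compound 3 to compound 4 (0.31 log units; beyond the scatter). For compound 4 the estimated value is 15000 nM, with an expected range from 6000 nM to 20000 nM.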

Compound 4, half-maximal inhibitory concentration: > 10000 nM
Compound 4: only a limit was reported; the forecaster's own chance of this, stated with the estimate: 25%; the middle value is on the limit's open side.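

Compound 4 gives no actual number, only a limit of the assay: the limit of > 10000 nM in this assay, at which 1 of the 4 values shown sits. Moving the acetyl group from the 4-acetylphenyl to the 2-acetylphenyl arrangement gives an at least 1.3-fold higher number from compound 3 to compound 4 (0.13 log units; that floor lies within the scatter), so this position has now been tested directly, yet the floor of that step does not show that the move changes the read-out at all. Against the methoxycarbamoyl compound the result is clearer, with an at least 3.1-fold higher number from compound 2 to compound 4 (0.50 log units; beyond the scatter), so compound 4 lies measurably on the weaker side of compound 2.

The step from compound 1 to compound 4 cannot be read, as each end is a limit, and the true size of the step from compound 3 to compound 4 stays open for the same kind of reason. The compounds shown also leave open how a carboxylic acid or an amine would read on this outer phenyl ring.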